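This account rests on a few compounds, and the source may have more. Where it says the series, first, only, none or still open, it means among the compounds named here.

In a functional assay on SW480 cells (Homo sapiens) for antiproliferative activity, read by sulforhodamine B assay, with a stated time of 48 h (on this read-out lower numbers stand for stronger inhibition and higher numbers for weaker inhibition), compound 1 `COc1ccc(OC)c(/C=C/C(=O)/C=C(O)/C=C/c2cc(OC)ccc2OC)c1` gives 15600 nM while compound 2 `COc1cc(C=C(C(=O)/C=C/c2cccc(OC)c2OC)C(=O)/C=C/c2cccc(OC)c2OC)ccc1O` gives 430 nM and so holds the lower of the two numbers, with a gap well beyond the usual scatter. Compound 3 `COc1cccc(/C=C/C(=O)C(=Cc2cc(OC)c(OC)c(OC)c2)C(=O)/C=C/c2cccc(OC)c2OC)c1OC` is still unmeasured. It carries 3,4,5-trimethoxyphenyl in place of 4-hydroxy-3-methoxyphenyl, counted as 3,4,5-trimethoxyphenyl in place of 4-hydroxy-3-methoxyphenyl on a double-bonded chain carbon bound to a double-bonded chain carbon on a double-bonded chain carbon bound to a double-bonded chain carbon. For the measured compounds named here, no measured pair shows this change. The expected step of a 1.9-fold higher number from compound 2 to compound 3 (0.27 log units; within the scatter) is a small rise in the number, close to the scatter. For compound 3 the estimated value is 800 nM with a range from 250 nM to 3000 nM as the expected span.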

Compound 3, half-maximal inhibitory concentration: 650 nM
The estimate for compound 3 lay 1.2-fold (0.09 log units) above the measured number, within the range that was stated.
By their numbers in this assay, from the lowest: compounds 2 and 3 (each within the scatter of the next); then compound 1.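

Putting 3,4,5-trimethoxyphenyl in place of 4-hydroxy-3-methoxyphenyl on a double-bonded chain carbon bound to a double-bonded chain carbon gives, in this assay, a 1.5-fold higher number from compound 2 to compound 3 (0.18 log units; within the scatter). For this one pair, then, the hydroxyl group and its hydrogen-bond donor can go, and a group with more heavy atoms can enter, without a change that can be told from the scatter. Nothing on hand explains this result. Still open, going by these compounds, is how this position would respond to a phenyl ring carrying an amine or a carboxylic acid, or to a plain phenyl ring with no oxygen-bearing groups.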